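Swapping the benzyl ring for pyridine in an mGlu5 modulator

The source may report more compounds than this note shows. Statements on the series, on what has been measured and on what is new or still open speak of the compounds shown alone.

Of the compounds shown here, two with a shared core have been measured in a functional assay on HEK293 cells for positive allosteric modulation of metabotropic glutamate receptor 5 (Homo sapiens), read by FLIPR and calcium flux; a lower number here means that less compound is needed, a higher number that more compound is needed for the effect. Compound 1 `O=C(COCc1ccccc1)N1CCN(c2cccc(Cl)c2)CC1` gives 6700 nM in this assay. Compound 2 `O=C(COCc1ccccc1)N1CCN(c2ccc(Cl)cc2)CC1` gives 350 nM in this assay. Among the measured compounds shown here, the only measured step, a 19-fold lower number from compound 1 to compound 2 (1.28 log units; beyond the scatter), is large and comes from moving the chlorine on the aryl ring; compound 2 therefore stands at the lower of the two numbers, with compound 1 the only neighbour.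

Compound 3 `O=C(COCc1ccncc1)N1CCN(c2ccc(Cl)cc2)CC1` keeps the 4-chlorophenyl of compound 2 and differs only at the far end of the molecule: pyridin-4-yl in place of phenyl on a saturated chain carbon bound to an oxygen on a saturated carbon. For the measured compounds named here, no measured step touches this part of the structure, so the one measured step, which concerns the aryl ring on the piperazine nitrogen, offers no direct guide. Exchanging one aromatic ring for another of the same size is usually a smaller change than moving a substituent, so for compound 3 in this assay a modest step is expected, a 2.0-fold higher number from compound 2 to compound 3 (0.30 log units; within the scatter), and its value is estimated at 700 nM, within a range from 200 nM to 3000 nM.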

Compound 3, half-maximal effective concentration: 1300 nM
Compound 3: middle estimate off by 1.9-fold (0.27 log units), on the low side; the range from low to high includes it.
By their numbers in this assay, from the lowest: compound 2; then compound 3; then compound 1.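

Among the compounds shown here, until now, the only change read was on the aryl ring at the amine nitrogen; this is the first reading at the far end of the molecule. In this assay, pyridin-4-yl in place of phenyl gives a 3.7-fold higher number from compound 2 to compound 3 (0.57 log units; beyond the scatter), so this end is not indifferent to the change, even though the ring keeps its size and its 6 heavy atoms, with one carbon replaced by a nitrogen that adds a hydrogen-bond acceptor to the count. The step is modest beside a 19-fold lower number from compound 1 to compound 2 (1.28 log units; beyond the scatter), so among the changes shown, moving the chlorine has the larger effect, and nothing measured here explains the rise seen with the pyridine.

Still open, from the compounds shown here alone, is whether this step belongs to pyridin-4-yl alone or to any ring nitrogen at this end, which pyridin-3-yl or pyridin-2-yl would help to separate. Also open, going by these compounds, is how far this end accepts other groups, such as a cyclohexyl ring or a phenyl carrying a fluorine, and whether the pyridine swap reads the same with the 3-chlorophenyl of compound 1.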